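The compounds below may be only part of what the source reports. "The series", "measured", "known", "first", "only" and "open" are said of these compounds alone.

Compound 1 `Cc1nc([C@H](NC(=O)c2ccc(-c3ccc(Cl)c(F)c3)[nH]2)[C@H]2CCCCN2)sc1CO`: 17400 nM
Compound 2 `Cc1ccc(-c2ccc(C(=O)N[C@@H](c3nc(C)c(CO)s3)[C@@H]3CCCCN3)[nH]2)cc1F`: 19200 nM

In a toxicity assay on TZM cells (Homo sapiens) for cytotoxicity, read by XTT assay, with a stated time of 3 days (on this read-out higher numbers stand for lower toxicity in this test and lower numbers for higher toxicity in this test), compound 2 gives 19200 nM, which lies within the usual scatter of compound 1 at 17400 nM. Compound 3 `Cc1ccc(-c2ccc(C(=O)N[C@@H](c3nc(C)c(CCO)s3)[C@@H]3CCCCN3)[nH]2)cc1F` differs from compound 2 in one place: hydroxymethyl in place of hydroxy on a saturated chain carbon bound to an aromatic carbon. This puts hydroxymethyl in place of hydroxy on a saturated chain carbon bound to an aromatic carbon, so hydroxymethyl becomes 2-hydroxyethyl. Among the measured compounds shown here, no measured pair shows this change, so nothing here points to a direction, and no step beyond the scatter is expected in this assay. The estimated 1.1-fold lower number from compound 2 to compound 3 (0.03 log units; within the scatter) stays within the scatter. For compound 3 the expected value is 18000 nM, with an estimated range of 9000 nM to 36000 nM.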

Compound 3, half-maximal cytotoxic concentration: 15300 nM
The estimate for compound 3 lay 1.2-fold (0.07 log units) above the measured number, within the range that was stated.
By their numbers in this assay, from the lowest: compounds 3, 1 and 2 (each within the scatter of the next).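

In this assay, among the compounds shown here, the change from hydroxymethyl to 2-hydroxyethyl gives a 1.3-fold lower number from compound 2 to compound 3 (0.10 log units; within the scatter) and is the first measured pair at this position. The longer chain, with one more carbon before the hydroxy, therefore brings no step beyond the scatter in this toxicity read-out. Nothing measured here explains this result.

The compounds shown leave open whether a still longer chain, such as 3-hydroxypropyl, would also stay within the scatter. They also leave open what an amine or a carboxylic acid in place of the hydroxy would do.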